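Amide series: carboxylic acid to isopropylamide

This account rests on a few compounds, and the source may have more. Where it says the series, first, only, none or still open, it means among the compounds named here.

Among the measured compounds shown here, compound 3 `COc1ccc2c(c1)OC(c1cc(OC)c(OC)c(OC)c1)C(C(=O)O)=C2` is the one member of the three measured so far that returns a limit rather than a number: in a functional assay for inhibition of nuclear factor NF-kappa-B complex (Homo sapiens) (on this read-out higher numbers stand for weaker inhibition and lower numbers for stronger inhibition), compound 3 gives > 50000 nM, which is the limit of > 50000 nM in this assay, at which 1 of the 3 values shown sits. Compound 1 `COc1ccc2c(c1)OC(c1cc(OC)c(OC)c(OC)c1)C(C(=O)N(C)OC)=C2` gives 11700 nM and compound 2 `COc1ccc2c(c1)OC(c1cc(OC)c(OC)c(OC)c1)C(C(=O)Nc1ccccc1)=C2` gives 17500 nM in this assay; the step of a 1.5-fold higher number from compound 1 to compound 2 (0.17 log units; within the scatter) stays within the scatter. Compound 4 `COc1ccc2c(c1)OC(c1cc(OC)c(OC)c(OC)c1)C(C(=O)NC(C)C)=C2` differs from compound 3 by isopropylamino in place of hydroxy on a carbonyl carbon. The steps of an at least 4.2-fold higher number from compound 1 to compound 3 (0.63 log units; beyond the scatter) and an at least 2.8-fold higher number from compound 2 to compound 3 (0.45 log units; beyond the scatter) bear on this change, both running from a carbonyl-attached nitrogen to hydroxy. Running the other way, a step of an at least 3.3-fold lower number from compound 3 to compound 4 (0.52 log units; beyond the scatter) is expected, toward stronger inhibition. For compound 4 the estimate in this assay is 15000 nM, within a range of 6000 nM to 40000 nM.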

Compound 4, half-maximal inhibitory concentration: > 50000 nM
Compound 4: no number, only a limit; the forecaster's own chance of this, stated with the estimate: 20%; at least 3.3-fold (0.52 log units) between middle value and limit.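

In this assay compound 4 returns only a limit, as compound 3 does: the limit of > 50000 nM in this assay, at which 2 of the 4 values shown sit. A nitrogen on the carbonyl carbon is therefore not enough to give a measurable number, since isopropyl in place of phenyl on the amide-type nitrogen gives an at least 2.8-fold higher number from compound 2 to compound 4 (0.45 log units; beyond the scatter) and isopropylamino in place of methoxy(methyl)amino gives an at least 4.2-fold higher number from compound 1 to compound 4 (0.63 log units; beyond the scatter). The step between the two limits cannot be read.

Open, going by these compounds, is whether methylamino, butylamino or morpholine on the carbonyl carbon would return a number in this assay and how it would sit against compound 1 and compound 2.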